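A fluorine added to a series stuck at the assay limit

The source may report more compounds than this note shows. Statements on the series, on what has been measured and on what is new or still open speak of the compounds shown alone.

The three measured compounds share one core and differ only in the group on the phenyl attached to it. In a functional assay on A549 cells (Homo sapiens) for antiproliferative activity, read by XTT assay, with a stated time of 24 h (a lower number here means a stronger inhibitor, a higher number a weaker inhibitor), compound 1 `CS(=O)(=O)c1ccc(-c2csc(N3N=C(c4ccc(Cl)s4)CC3c3ccc(F)cc3)n2)cc1` gives > 500 ug/mL, which is a limit of the assay rather than a number. Compound 2 `N#Cc1ccc(-c2csc(N3N=C(c4ccc(Cl)s4)CC3c3ccc(F)cc3)n2)cc1` gives > 500 ug/mL in this assay, again a limit. Compound 3 `Fc1ccc(C2CC(c3ccc(Cl)s3)=NN2c2nc(-c3ccccc3)cs2)cc1` likewise gives > 500 ug/mL in this assay, also a limit. Compound 3 therefore stands where the whole series stands: the steps a step that the two limits leave unreadable from compound 1 to compound 2, a step that the two limits leave unreadable from compound 1 to compound 3 and a step that the two limits leave unreadable from compound 2 to compound 3 cannot be read because of the limit of > 500 ug/mL in this assay, at which 3 of the 3 values shown sit.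

Compound 4 `Fc1ccc(-c2csc(N3N=C(c4ccc(Cl)s4)CC3c3ccc(F)cc3)n2)cc1` differs from compound 3 by fluoro in place of hydrogen on an aromatic carbon. Among the measured compounds shown here, none of the measured steps gives a readable size or direction, so nothing points to a change beyond the scatter. Compound 4 is expected to give about 500 ug/mL in this assay, with a range from 150 ug/mL to 1500 ug/mL. The step of a number no higher from compound 3 to compound 4 (the limit leaves the size open) this estimate implies is expected to be none beyond the scatter, with the value most likely reported once more as a limit.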

Compound 4, half-maximal inhibitory concentration: > 500 ug/mL
Compound 4: no number, only a limit (the forecaster's own chance of this, stated with the estimate: 85%); the middle value lies on the limit itself.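

No step between compound 4 and compound 1, compound 2 or compound 3 can be read in this assay, because each value is a limit and not a number: the limit of > 500 ug/mL in this assay, at which 4 of the 4 values shown sit.

The compounds shown leave open how these four compare with one another, and whether any group on this phenyl would give a number.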